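Iodo for methyl on the aryl of compound 1

This account rests on a few compounds, and the source may have more. Where it says the series, first, only, none or still open, it means among the compounds named here.

Working notes on the series. Three compounds have numbers in an assay on HEK-293T cells for displacement of a labelled ligand from corticotropin-releasing factor receptor 1 (Homo sapiens), read by scintillation counting, with a stated time of 2 h; a higher number here means a weaker inhibitor, a lower number a stronger inhibitor. Compound 1 `CCCCN(CC)c1cc(C)nc2c1NC(=O)CN2c1ccc(C)cc1C` gives 3.9 nM in this assay. Compound 2 `CCCCN(CC)c1cc(C)nc2c1NC(=O)CN2c1ccc(C(C)C)cc1Br` gives 2.4 nM, and compound 3 `Cc1cc(N(C)C)c2c(n1)N(c1ccc(C(C)C)cc1Br)CC(=O)N2CCCCF` gives 21.6 nM. Compound 1 stands second highest of the three; its number and that of compound 2 lie within the scatter of each other, so no order between them is claimed, while compound 3 sits beyond the scatter on the higher side.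

The next compound, compound 4 `CCCCN(CC)c1cc(C)nc2c1NC(=O)CN2c1ccc(I)cc1C`, is not yet measured. It differs from compound 1 in one place: iodo in place of methyl on an aromatic carbon. Going by the values given here, no single-change step between measured compounds is available to calibrate this exchange, so the expectation rests on the structures alone. One heavy atom is swapped for one heavy atom, with no change in ring count, donors, acceptors or charge. The expected step in this assay from compound 1 to compound 4 is a 1.1-fold lower number from compound 1 to compound 4 (0.05 log units; within the scatter), that is, no step beyond the scatter in either direction. Compound 4 is estimated at 3.5 nM, with a range from 1.2 nM to 10 nM.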

Compound 4, inhibition constant: 3.4 nM
Compound 4: the middle estimate sits 1.0-fold (0.01 log units) above what was measured, within the range that was stated.
By their numbers in this assay, from the lowest: compounds 2, 4 and 1 (each within the scatter of the next); then compound 3.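

In this assay, going by these compounds alone, iodo in place of methyl on the aromatic carbon para to a large group gives a 1.1-fold lower number from compound 1 to compound 4 (0.06 log units; within the scatter) and so provides the first single-change step. Within the data shown here, at this position, on the core of compound 1, the step from methyl to iodo stays within the scatter, which the earlier compounds, differing from one another in more than one place, could not show. Nothing at hand bears on why the number holds across this exchange.

Methyl and iodo are only two groups at this position, so an amine, a carboxylic acid, a methoxy group or a longer chain there remains open. Also open, on these data alone, is whether the same exchange would stay within the scatter with a group other than the methyl group meta to it, or with another chain on the amide nitrogen.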